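The source may report more compounds than this note shows. Statements on the series, on what has been measured and on what is new or still open speak of the compounds shown alone.

In a functional assay on Venous blood for antagonist activity at C-X-C chemokine receptor type 3 (Homo sapiens), read by flow cytometry, with a stated time of 30 min, in the presence of a further agent that is not named here (a higher number here means a weaker inhibitor, a lower number a stronger inhibitor), compound 1 `Cc1nn(CC(=O)N2CCN(c3sc(C(F)(F)F)nc3-c3nc4ccccc4[nH]3)C[C@H]2C)cc1CN(C)C` gives 330 nM, the higher of the two numbers recorded so far. Compound 2 `C[C@@H]1CN(c2sc(C(F)(F)F)nc2-c2nc3ccc(CO)cc3[nH]2)CCN1C(=O)Cn1cnc2cccnc21` gives 92.4 nM in this assay, and the two compounds differ at more than one place, so their values are compared only as they stand. Compound 3 `C[C@@H]1CN(c2sc(C(F)(F)F)nc2-c2nc3ccccc3[nH]2)CCN1C(=O)Cn1cc(C2CCN(C)CC2)cn1` carries 4-(1-methylpiperidin-4-yl)-1H-pyrazol-1-yl in place of 4-((dimethylamino)methyl)-3-methyl-1H-pyrazol-1-yl on a saturated chain carbon bound to a carbonyl carbon. Because compound 1 gives 330 nM and the two compounds are otherwise the same, the step is expected to be a 1.3-fold lower number from compound 1 to compound 3 (0.12 log units; within the scatter), so no change beyond the scatter is expected. Compound 3 is estimated at 250 nM, within 80 nM to 800 nM.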

Compound 3, half-maximal inhibitory concentration: 1690 nM
The estimate for compound 3 lay 6.8-fold (0.83 log units) below the measured number; the whole stated range lies below it.
By their numbers in this assay, from the lowest: compound 2; then compound 1; then compound 3.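

In this assay, this position on a saturated chain carbon bound to a carbonyl carbon proves sensitive to the choice of pyrazole substituent: 4-(1-methylpiperidin-4-yl)-1H-pyrazol-1-yl in place of 4-((dimethylamino)methyl)-3-methyl-1H-pyrazol-1-yl gives a 5.1-fold higher number from compound 1 to compound 3 (0.71 log units; beyond the scatter). The step appears even though the two groups have the same counts of hydrogen-bond donors and acceptors. No measurement at hand explains it.

On these data alone, the ring amine and the loss of the methyl group change together in this step, so their separate contributions remain open. As far as these compounds go, how a morpholine or a pyrrolidine on the pyrazole would compare also remains open.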